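This account rests on a few compounds, and the source may have more. Where it says the series, first, only, none or still open, it means among the compounds named here.

Compound 2 `COc1ccc2nc(Nc3nc(Nc4ccc(S(C)(=O)=O)cc4)ncc3F)sc2c1` and compound 1 `CS(=O)(=O)c1ccc(Nc2ncc(F)c(Nc3nc4ccccc4s3)n2)cc1` share one core. In a functional assay on PC-3 cells (Homo sapiens) for antiproliferative activity, read by MTT assay, with a stated time of 48 h (on this read-out higher numbers stand for weaker inhibition and lower numbers for stronger inhibition), compound 2 gives 1270 nM, and compound 1 gives 2830 nM. The step of a 2.2-fold higher number from compound 2 to compound 1 (0.35 log units; beyond the scatter) goes with the change (hydrogen in place of methoxy on an aromatic carbon). Compound 3 `COc1ccc2nc(Nc3ccnc(Nc4ccc(S(N)(=O)=O)cc4)n3)sc2c1` rests on a second core; the difference between the two cores is not broken down here. In this assay compound 3 gives 3030 nM, a number within the usual scatter of that of compound 1. Compound 4 `NS(=O)(=O)c1ccc(Nc2nccc(Nc3nc4ccccc4s3)n2)cc1` arises from compound 3 by the same change, (hydrogen in place of methoxy on an aromatic carbon), at the same place. Because the earlier step was a 2.2-fold higher number from compound 2 to compound 1 (0.35 log units; beyond the scatter), the step from compound 3 to compound 4 is expected to be of similar size, a 2.1-fold higher number from compound 3 to compound 4 (0.33 log units; beyond the scatter). Compound 4 is therefore estimated to give about 6500 nM, most likely between 3000 nM and 15000 nM.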

Compound 4, half-maximal inhibitory concentration: 3100 nM
Compound 4: middle estimate off by 2.1-fold (0.32 log units), on the high side; the measured number falls inside the stated range.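

In this assay, putting hydrogen in place of methoxy gives a 1.0-fold higher number from compound 3 to compound 4 (0.01 log units; within the scatter), while the same change on the other core gives a 2.2-fold higher number from compound 2 to compound 1 (0.35 log units; beyond the scatter). Only the second of these steps lies beyond the scatter, yet the two steps cannot be told apart from each other: the same change on two cores in this assay, a 2.2-fold higher number (0.35 log units; beyond the scatter) from compound 2 to compound 1 and a 1.0-fold higher number (0.01 log units; within the scatter) from compound 3 to compound 4, 2.2-fold (0.34 log units) apart, within the scatter of two such steps. This means the change may behave alike on both cores, but a single pair of steps neither proves that it carries over nor shows that it fails to.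

The compounds shown leave open how an amine, a chlorine atom or an ethoxy group at this place would behave in this assay. They also leave open whether either core would respond more strongly to such groups.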